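This account rests on a few compounds, and the source may have more. Where it says the series, first, only, none or still open, it means among the compounds named here.

Compound 1 `O=C(NC1CCc2n[nH]cc2C1)[C@@H]1CCCN1C(=O)[C@@H](CC1CCCCC1)NS(=O)(=O)Cc1ccccc1` reaches only the limit > 68300 nM in an assay on isolated protein for inhibition of serine protease 1 (Homo sapiens); a lower number here means a stronger inhibitor, a higher number a weaker inhibitor. Compound 2 `Cn1cc2c(n1)CCC(NC(=O)[C@@H]1CCCN1C(=O)[C@@H](CC1CCCCC1)NS(=O)(=O)Cc1ccccc1)C2` gives 730000 nM in this assay.

Going by the values given here, compound 2 therefore holds the only real number in this assay; the remaining value is a limit. The step that the limit leaves unreadable from compound 1 to compound 2 cannot be read. Compound 3 `Nc1ncc2c(n1)CCC(NC(=O)[C@@H]1CCCN1C(=O)[C@@H](CC1CCCCC1)NS(=O)(=O)Cc1ccccc1)C2` differs from compound 2 by a group of 11 heavy atoms (8 carbon, 3 nitrogen; one six-membered non-aromatic ring of carbon only, one six-membered aromatic ring with 2 hetero atoms) in place of a group of 10 heavy atoms (8 carbon, 2 nitrogen; one five-membered aromatic ring with 2 hetero atoms, one six-membered non-aromatic ring of carbon only), on an amide-type nitrogen. No measured step covers such a swap, and the single step shown is unreadable, so no direction beyond the scatter is expected in this assay. Compound 3 is expected near 400000 nM, between 40000 nM and 4000000 nM. The estimated step is a 1.8-fold lower number from compound 2 to compound 3 (0.26 log units; within the scatter).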

Compound 3, inhibition constant: > 68300 nM
Compound 3 ended at the assay's limit; the forecaster's own chance of this, stated with the estimate: 40%; the middle value does not contradict the limit.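

Going by these compounds alone, compound 3 gives only a limit (> 68300 nM), so no step from compound 1 or compound 2 to compound 3 can be read: (the limit of > 68300 nM in this assay, at which 2 of the 3 values shown sit). In this assay the compounds shown leave open the true numbers of compound 1 and compound 3, and so whether these group swaps change anything.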